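Returning an aromatic ring to the tail of compound 2

The source may hold more compounds than are shown below. What is called first, only, known or untested is meant among the compounds shown, and "the series" means these compounds.

Measured compounds:
- compound 1, `CCC(C)(C)Cc1c[nH]c(CCc2ccc(-c3cnccn3)cc2)n1`, 11 nM
- compound 2, `CCC(C)(C)Cc1c[nH]c(CCc2ccc(N3CCCCC3)cc2)n1`, 28 nM
- compound 3, `O=C(O)c1cc(F)c(F)cc1-c1ccc(CCc2nc(CC3CCCCC3)c[nH]2)cc1`, 4.7 nM

All three were tested in a functional assay on HEK293 cells for agonist activity at Bombesin receptor subtype-3 (Mus musculus), read by luminescence and calcium flux, with a stated time of 10 min; a higher number here means that more compound is needed for the effect, a lower number that less compound is needed. Compound 2 stands highest of the three numbers: compound 1 is nearest, and compound 3 lies furthest away with its lower value. Within the data shown here, the one single-point step available is a 2.5-fold higher number from compound 1 to compound 2 (0.41 log units; beyond the scatter), which shows that trading the aromatic pyrazin-2-yl ring for the saturated piperidin-1-yl ring raised the number beyond the scatter.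

The unmeasured compound 4, `CCC(C)(C)Cc1c[nH]c(CCc2ccc(-c3ccc(F)cn3)cc2)n1`, reverses that kind of change: 5-fluoropyridin-2-yl in place of piperidin-1-yl on an aromatic carbon. Since the entering group is again a six-membered aromatic ring with one nitrogen, the step from compound 1 to compound 2 is the relevant precedent, and it is expected to run in the opposite direction, giving a modest fall in the number. For compound 4 the estimated step is a 2.3-fold lower number from compound 2 to compound 4 (0.37 log units; beyond the scatter). Compound 4 is therefore expected to give about 12 nM, within a range from 5 nM to 30 nM.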

Compound 4, half-maximal effective concentration: 16 nM
Compound 4: middle estimate off by 1.3-fold (0.12 log units), on the low side; measured number inside the range.
By their numbers in this assay, from the lowest: compound 3; then compounds 1, 4 and 2 (each within the scatter of the next, the first and the last beyond it).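

In this position, the 5-fluoropyridin-2-yl ring of compound 4 cannot be told apart from the piperidin-1-yl ring (a 1.8-fold lower number from compound 2 to compound 4 (0.24 log units; within the scatter)). It also cannot be told apart from the pyrazin-2-yl ring (a 1.5-fold higher number from compound 1 to compound 4 (0.16 log units; within the scatter)), so compound 4 sits within the scatter of both neighbours, although compounds 1 and 2 themselves differ beyond it; swapping a saturated ring for an aromatic one therefore did not reproduce a clear separation here, and nothing shown gives a reason for this.

Going by these compounds, what the fluorine contributes stays open, as a plain pyridin-2-yl ring would be needed for that comparison. Also open, on these data alone, is whether a carboxylic acid on this outer ring would help with the 3,3-dimethylbutyl-type tail kept, since compound 3 differs from these compounds in more than one place.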